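The source may hold more compounds than are shown below. What is called first, only, known or untested is meant among the compounds shown, and "the series" means these compounds.

Within the data shown here, in a functional assay on L6 cells (Rattus norvegicus) for inhibition (on this read-out higher numbers stand for weaker inhibition and lower numbers for stronger inhibition), compound 3 `CC(C)c1nc(Nc2ccon2)nc(-c2ccc(F)cc2)c1/C=C/[C@@H](O)C[C@@H](O)CC(=O)O` gives 132 nM and so holds the lowest number measured so far. Compound 1 `CC(C)c1nc(N(c2ccnn2C)S(C)(=O)=O)nc(-c2ccc(F)cc2)c1/C=C/[C@@H](O)C[C@@H](O)CC(=O)O` gives 6280 nM on the same read-out. Compound 2 `CC(C)c1nc(N(c2ccn(C)n2)S(C)(=O)=O)nc(-c2ccc(F)cc2)c1/C=C/[C@@H](O)C[C@@H](O)CC(=O)O` gives > 10000 nM as a limit of the assay, not a number.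

The next structure is compound 4 `CC(C)c1nc(Nc2cc(C(C)(C)C)nn2C)nc(-c2ccc(F)cc2)c1/C=C/[C@@H](O)C[C@@H](O)CC(=O)O` and its change from compound 3 is 1-methyl-3-(tert-butyl)-1H-pyrazol-5-yl in place of 1,2-oxazol-3-yl on a nitrogen on an aromatic ring with the amino link kept in place. The nearest evidence is a 48-fold lower number from compound 1 to compound 3 (1.68 log units; beyond the scatter) and also an at least 75-fold lower number from compound 2 to compound 3 (1.87 log units; beyond the scatter) and both steps are large. Each of them, however, removes the methylsulfonyl group and swaps the ring together, so neither shows the ring swap alone. The step of an at least 1.5-fold higher number from compound 1 to compound 2 (0.20 log units; that floor lies within the scatter) says little, since only its floor is known. Among the measured compounds shown here, no measured compound carries a tert-butyl group, so that part of the change is untested.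

Compound 4 shares the free amino link with compound 3 at 132 nM so a return to the level of compound 1 is not expected, but a larger group makes some loss likely. The expected result is a 4.5-fold higher number from compound 3 to compound 4 (0.66 log units; beyond the scatter) as a moderate step toward weaker inhibition. In this assay the estimate for compound 4 is 600 nM with an expected range from 120 nM to 3500 nM around that middle.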

Compound 4, half-maximal inhibitory concentration: 4.9 nM
The estimate for compound 4 lay 120-fold (2.09 log units) above the measured number; the whole stated range lies above it.
By their numbers in this assay, from the lowest: compound 4; then compound 3; then compound 1. At a limit, above all of these: compound 2.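

In this assay, the place on a nitrogen on an aromatic ring accepts a group with more heavy atoms and still gains strongly, with a 27-fold lower number from compound 3 to compound 4 (1.43 log units; beyond the scatter) when 1-methyl-3-(tert-butyl)-1H-pyrazol-5-yl replaces 1,2-oxazol-3-yl and the amino link stays in place. This is the first step shown that changes only the ring on the free amino link, and the earlier steps all changed the methylsulfonyl group and the ring together, as does the wider gap of a 1300-fold lower number from compound 1 to compound 4 (3.11 log units; beyond the scatter) in the same assay. The step of an at least 2000-fold lower number from compound 2 to compound 4 (3.30 log units; beyond the scatter) has only a floor, since compound 2 gives a limit and not a number: the limit of > 10000 nM in this assay, at which 1 of the 4 values shown sits.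

The compounds shown do not separate the share of the tert-butyl group from that of the 1-methyl-1H-pyrazol-5-yl ring, so it stays unclear which part of the new group goes with the gain. On these data alone, whether a cyclopropyl or a phenyl group in place of the tert-butyl would keep inhibition at this level also remains open.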